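The source may report more compounds than this note shows. Statements on the series, on what has been measured and on what is new or still open speak of the compounds shown alone.

Measured in a functional assay on blood (Homo sapiens), with a stated time of 60 min, in the presence of a further agent that is not named here; a lower number here means that less compound is needed, a higher number that more compound is needed for the effect:
- Compound 1 `O=S(=O)(c1ccc(Oc2ccc(OC(F)(F)F)cc2)cc1)C1CCC2(CCNCC2)C1`: > 15000 nM (a limit)
- Compound 2 `O=C(O)C1(S(=O)(=O)c2ccc(Oc3ccc(OC(F)(F)F)cc3)cc2)CCC2(CCNCC2)C1`: 1800 nM
- Compound 3 `O=C(Nc1ccccc1O)C1(S(=O)(=O)c2ccc(Oc3ccc(OC(F)(F)F)cc3)cc2)CCC2(CCNCC2)C1`: > 15000 nM (a limit)

Compound 3 has no exact number, only the limit > 15000 nM. This is the limit of > 15000 nM in this assay, at which 2 of the 3 values shown sit.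

Compound 4 `CS(=O)(=O)NC(=O)C1(S(=O)(=O)c2ccc(Oc3ccc(OC(F)(F)F)cc3)cc2)CCC2(CCNCC2)C1` is the next analogue to be tested in this assay. Its difference from compound 3 is methylsulfonyl in place of 2-hydroxyphenyl on an amide-type nitrogen. In words, methylsulfonyl stands in place of 2-hydroxyphenyl on an amide-type nitrogen, so (2-hydroxyphenyl)carbamoyl becomes (methylsulfonyl)carbamoyl.

For the measured compounds named here, no measured step makes this exact exchange, so the evidence is indirect. Carboxy in place of hydrogen gave an at least 8.3-fold lower number from compound 1 to compound 2 (0.92 log units; beyond the scatter), a gain beyond the scatter. Putting (2-hydroxyphenyl)amino in place of hydroxy then gave an at least 8.3-fold higher number from compound 2 to compound 3 (0.92 log units; beyond the scatter), which undid that gain as far as the limit shows. The step that the two limits leave unreadable from compound 1 to compound 3 adds nothing further.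

Compound 4 gives up the 2-hydroxyphenyl group but keeps the carbonyl, so some recovery toward compound 2 at 1800 nM is expected, probably not all of it. The direction expected is therefore toward a lower number, with a modest size that remains uncertain. The expected change is an at least 3.7-fold lower number from compound 3 to compound 4 (0.57 log units; beyond the scatter). For compound 4 the estimated value is 4000 nM, with an expected range from 1000 nM to 14000 nM.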

Compound 4, half-maximal effective concentration: > 15000 nM
Compound 4: a limit, no number; the forecaster's own chance of this, stated with the estimate: 25%; middle value at least 3.7-fold (0.57 log units) away from the limit.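

In this assay, methanesulfonamido in place of hydroxy on a carbonyl carbon gave an at least 8.3-fold higher number from compound 2 to compound 4 (0.92 log units; beyond the scatter), so the gain from the carboxy group did not survive this exchange either. Two different groups on the amide-type nitrogen have now led to the same outcome, the 2-hydroxyphenyl group with its six-membered aromatic ring and the methylsulfonyl group with no ring, so giving up the 2-hydroxyphenyl group did not by itself bring a readable number back. Compound 4 has a limit and not a number, and it joins compounds 1 and 3 at the same limit: the limit of > 15000 nM in this assay, at which 3 of the 4 values shown sit.

From the compounds shown here alone, the steps from compound 3 to compound 4 and from compound 1 to compound 4 cannot be read, as both ends of each are limits, and how far these three compounds lie from one another stays open. For the compounds shown here, also open is whether a tetrazole or a methyl ester in place of the carboxy group would give a readable number in this assay, and how that number would compare with the one for compound 2.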